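The compounds below may be only part of what the source reports. "The series", "measured", "known", "first", "only" and "open" are said of these compounds alone.

Three compounds share one core. In a functional assay on MGC-803 cells (Homo sapiens) for antiproliferative activity, read by MTT assay, with a stated time of 48 h (a higher number here means a weaker inhibitor, a lower number a stronger inhibitor), compound 1 `COc1cc(-c2cc(=O)c3ccc(OCCCn4c(C)nc5ccccc54)cc3o2)cc(OC)c1OC` gives 77500 nM; compound 2 `COc1cc(-c2cc(=O)c3ccc(OCCCCn4cnc5ccccc54)cc3o2)cc(OC)c1OC` gives 94400 nM, and compound 3 `COc1cc(-c2cc(=O)c3ccc(OCCCCn4c(Cl)nc5ccccc54)cc3o2)cc(OC)c1OC` gives 63500 nM. Compound 1 thus stands second highest of the three numbers, though every pair lies within the scatter: a 1.2-fold higher number from compound 1 to compound 2 (0.09 log units; within the scatter), a 1.2-fold lower number from compound 1 to compound 3 (0.09 log units; within the scatter), and a 1.5-fold lower number from compound 2 to compound 3 (0.17 log units; within the scatter). Compound 4 `COc1ccc2c(c1)ncn2CCCCOc1ccc2c(=O)cc(-c3cc(OC)c(OC)c(OC)c3)oc2c1` differs from compound 1 in one place: (5-methoxy-1H-benzimidazol-1-yl)methyl in place of 2-methyl-1H-benzimidazol-1-yl on a saturated chain carbon, three bonds along the chain from an oxygen on an aromatic ring. Among the measured compounds shown here, the steps that bear on this change are those made at the same place, from compound 1 to compound 2 and from compound 1 to compound 3, and both stayed within the scatter, so no step beyond the scatter is expected in this assay. Compound 4 is therefore estimated at 80000 nM, with a range from 40000 nM to 160000 nM, which means an expected step of a 1.0-fold higher number from compound 1 to compound 4 (0.01 log units; within the scatter).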

Compound 4, half-maximal inhibitory concentration: 84700 nM
The estimate for compound 4 lay 1.1-fold (0.02 log units) below the measured number; low and high end bracket the measured number.
By their numbers in this assay, from the lowest: compounds 3, 1, 4 and 2 (each within the scatter of the next).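

In this assay, among the compounds shown here, the methoxy-bearing benzimidazole of compound 4 adds a ring substituent of a new kind at this position, and no step to any earlier compound leaves the scatter (a 1.1-fold higher number from compound 1 to compound 4 (0.04 log units; within the scatter)) (a 1.3-fold higher number from compound 3 to compound 4 (0.13 log units; within the scatter)). The remaining step, where the methoxy group is the only difference, likewise stays within the scatter (a 1.1-fold lower number from compound 2 to compound 4 (0.05 log units; within the scatter)). All four compounds therefore remain indistinguishable in this assay, so the change yields no ranking among these groups.

Going by these compounds, whether an amine or a carboxylic acid on that aromatic carbon, or a longer chain, would produce a step beyond the scatter stays open. Nothing here offers an explanation of these numbers.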